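A Methoxy Swap on the Highest-Clearance Compound

A few compounds are considered here, and "the series" means these few. Any claim that something is new, unique, unknown or untested is made for them only; others in the source may bear on it.

In an ADME assay (liver) for metabolic stability, with Liver microsome (Rattus norvegicus) as the target, using microsomes (on this read-out higher numbers stand for fast clearance and lower numbers for slow clearance), compound 1 `O=C(O)c1csc(-n2nc(-c3ccccc3)c3cccnc32)n1` gives 65 mL/min/kg and compound 2 `O=C(O)c1csc(-n2nc(-c3ccccc3)c3ccncc32)n1` gives 69 mL/min/kg as a pair within the usual scatter of each other. Compound 3 `O=C(O)c1csc(-n2nc(-c3ccccc3)c3ccc(F)cc32)n1` gives 337 mL/min/kg and stands highest of the three, beyond the scatter from both other compounds.

The next compound to be read is compound 4 `COc1ccc2c(-c3ccccc3)nn(-c3nc(C(=O)O)cs3)c2c1`, which carries methoxy in place of fluoro on an aromatic carbon, meta to a fused ring and para to a fused ring, with methoxy in place of fluoro on an aromatic carbon as the counted change. No measured pair among these compounds differs in one place, so the data offer no direct precedent for this change. The expectation in this assay therefore stays anchored on compound 3 at 337 mL/min/kg as the closest measured reference. The estimated step of a 1.2-fold lower number from compound 3 to compound 4 (0.07 log units; within the scatter) stays within the scatter. Compound 4 is expected at 290 mL/min/kg with an estimated range from 120 mL/min/kg to 620 mL/min/kg as its limits.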

Compound 4, clearance: 196 mL/min/kg
Compound 4: the middle estimate sits 1.5-fold (0.17 log units) above what was measured; the range from low to high includes it.
By their numbers in this assay, from the lowest: compounds 1 and 2 (each within the scatter of the next); then compounds 4 and 3 (each within the scatter of the next).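

Going by these compounds alone, compounds 3 and 4 form the first pair that differs in one place, and in this assay methoxy in place of fluoro gives a 1.7-fold lower number from compound 3 to compound 4 (0.24 log units; within the scatter) and so stays within the scatter. At this aromatic carbon, meta to a fused ring and para to a fused ring, the read-out therefore does not separate the two groups, even though methoxy brings a hydrogen-bond acceptor that fluoro, as counted here, does not. The data shown offer no measured basis for explaining this outcome.

On these data alone, it remains open whether a hydrogen, an amine, a nitrile or a longer chain such as ethoxy at this carbon would read apart from fluoro and methoxy. Also open, as far as these compounds go, is whether methoxy in place of fluoro would give a similar step on another core or at another aromatic carbon.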